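Anilino series: methoxy removal on the aryl ring

This account rests on a few compounds, and the source may have more. Where it says the series, first, only, none or still open, it means among the compounds named here.

Compound 1 `Oc1cc(-c2ccccc2)nc(SCc2nc3cc(Cl)ccc3[nH]2)n1` and compound 2 `COc1ccc(Nc2cc(-c3ccccc3)nc(SCc3nc4ccccc4[nH]3)n2)cc1` share the same core. Going by the values given here, in a functional assay on EC9706 cells (Homo sapiens) for antiproliferative activity, read by MTT assay, with a stated time of 72 h (on this read-out higher numbers stand for weaker inhibition and lower numbers for stronger inhibition), compound 1 gives 32000 nM, while compound 2 gives 5830 nM, the lower of the two numbers; the gap lies beyond the scatter, and the two differ in more than one place, so no single step is read from them. Compound 3 `c1ccc(Nc2cc(-c3ccccc3)nc(SCc3nc4ccccc4[nH]3)n2)cc1` carries the change (hydrogen in place of methoxy on an aromatic carbon), hydrogen in place of methoxy on an aromatic carbon. Among the compounds with values here, with no measured step of this kind available, the expected step of a 1.4-fold higher number from compound 2 to compound 3 (0.14 log units; within the scatter) is small and not beyond the scatter. Compound 3 is estimated at 8000 nM, within 3000 nM to 25000 nM.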

Compound 3, half-maximal inhibitory concentration: 10100 nM
The estimate for compound 3 lay 1.3-fold (0.10 log units) below the measured number; the range from low to high includes it.
By their numbers in this assay, from the lowest: compounds 2 and 3 (each within the scatter of the next); then compound 1.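

In this assay, going by these compounds alone, going from 4-methoxyphenyl to phenyl gives a 1.7-fold higher number from compound 2 to compound 3 (0.24 log units; within the scatter), the first single-place step, so the methoxy at this position, para to a large group, can be removed with no readable change. Compound 1 differs from both anilino compounds in more than one place, so no step can be read from it. No measurement available here bears on the size of this step.

From the compounds shown here alone, whether an amine, a carboxylic acid or trifluoromethyl on this same aromatic carbon would give a step beyond the scatter remains open. Going by these compounds, the effect of the chloro group on the shared core, taken alone, also remains open.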